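Flat sulfonyl aryl series: from compound 3 to compound 4

A few compounds are considered here, and "the series" means these few. Any claim that something is new, unique, unknown or untested is made for them only; others in the source may bear on it.

Measured so far:
- compound 1 `CCn1cc(C(=O)O)c(=O)c2cc(F)c(N3CCN(C(=N)NS(=O)(=O)c4ccc(C(F)(F)F)cc4)CC3)cc21`: 32 nM
- compound 2 `Cc1ccc(S(=O)(=O)NC(=N)N2CCN(c3cc4c(cc3F)c(=O)c(C(=O)O)cn4C3CC3)CC2)cc1`: 32 nM
- compound 3 `N=C(NS(=O)(=O)c1ccccc1Cl)N1CCN(c2cc3c(cc2F)c(=O)c(C(=O)O)cn3C2CC2)CC1`: 32 nM

All three values come from a functional assay on HeLa cells (Homo sapiens) for antiproliferative activity, read by MTT assay, with a stated time of 72 h; on this read-out lower numbers stand for stronger inhibition and higher numbers for weaker inhibition. Compound 3 stands level with compound 1 and compound 2 at the digits available, so it offers no separation within this small set.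

The next structure, compound 4 `N=C(NS(=O)(=O)c1ccc(C(F)(F)F)cc1)N1CCN(c2cc3c(cc2F)c(=O)c(C(=O)O)cn3C2CC2)CC1`, differs from compound 3 as follows: 4-(trifluoromethyl)phenyl in place of 2-chlorophenyl on a sulfonyl sulfur. In words, 4-(trifluoromethyl)phenyl stands in place of 2-chlorophenyl on a sulfonyl sulfur.

For the measured compounds named here, only one measured step bears directly on this place: no change at the digits printed from compound 2 to compound 3 (within the scatter). That exchange, 2-chlorophenyl in place of 4-methylphenyl on a sulfonyl sulfur, stayed within the scatter. Compound 1 also carries 4-(trifluoromethyl)phenyl on a sulfonyl sulfur, and compound 1 gives 32 nM, level with compound 3.

In this assay, no change beyond the scatter is therefore expected, in either direction. The expected size is no change at the digits printed from compound 3 to compound 4 (within the scatter). For compound 4 the estimate is 32 nM, with an expected range from 15 nM to 70 nM.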

Compound 4, half-maximal inhibitory concentration: 32 nM
Estimate against measurement, compound 4: no gap at the digits printed, within the range that was stated.
By their numbers in this assay, from the lowest: compounds 1, 2, 3 and 4 (each within the scatter of the next).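

In this assay the exchange on the sulfonyl sulfur gives no change at the digits printed from compound 3 to compound 4 (within the scatter) and so does not separate 4-(trifluoromethyl)phenyl from 2-chlorophenyl at this place. Trifluoromethyl in place of methyl on an aromatic carbon gives no change at the digits printed from compound 2 to compound 4 (within the scatter) and adds a direct comparison on the same aryl group, while cyclopropyl in place of ethyl on an aromatic nitrogen gives no change at the digits printed from compound 1 to compound 4 (within the scatter) and extends the flat picture beyond the sulfonyl aryl group. No available evidence bears on why these exchanges leave the read-out level.

The compounds shown leave open whether this level would hold with a longer alkyl chain in place of the aryl group on the sulfonyl sulfur, or with an amine on that aryl group. They also leave open what an ester in place of the carboxylic acid would do.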